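A few compounds are considered here, and "the series" means these few. Any claim that something is new, unique, unknown or untested is made for them only; others in the source may bear on it.

In a functional assay on KBVIN cells (Homo sapiens) for antiproliferative activity, read by sulforhodamine B assay, with a stated time of 3 days (on this read-out lower numbers stand for an effect already at smaller amounts and higher numbers for an effect only at larger amounts of compound), compound 1 (`CCC1=C(O)c2c(oc(-c3ccccc3C)cc2=O)C(CC)(CC)C1=O`) gives 2.41 uM and compound 2 (`CCC1=C(O)c2c(oc(-c3cc(C)c(C)cc3C)cc2=O)C(CC)(CC)C1=O`) gives 4.37 uM, so compound 2 stands level with compound 1 within the scatter. Compound 3 (`CCC1=C(O)c2c(oc(-c3ccc(O)c(C)c3C)cc2=O)C(CC)(CC)C1=O`) differs from compound 2 as follows: 4-hydroxy-2,3-dimethylphenyl in place of 2,4,5-trimethylphenyl on an aromatic carbon. Among the compounds with values here, the one measured step, a 1.8-fold higher number from compound 1 to compound 2 (0.26 log units; within the scatter), exchanged one substituted phenyl group for another on that same aromatic carbon. Within the data shown here, no measured compound carries the 4-hydroxy-2,3-dimethylphenyl group, so no step beyond the scatter is expected in this assay. The estimated value for compound 3 is 3.5 uM, with an expected range of 1.2 uM to 10 uM. This estimate means an expected 1.2-fold lower number from compound 2 to compound 3 (0.10 log units; within the scatter).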

Compound 3, concentration for half-maximal effect: 2.75 uM
Compound 3: middle estimate off by 1.3-fold (0.10 log units), on the high side; measured number inside the range.
By their numbers in this assay, from the lowest: compounds 1, 3 and 2 (each within the scatter of the next).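

In this assay, the 4-hydroxy-2,3-dimethylphenyl group brings a hydrogen-bond donor and acceptor to this aromatic carbon, where the two earlier groups carry neither, yet the step is a 1.6-fold lower number from compound 2 to compound 3 (0.20 log units; within the scatter). Against the 2-methylphenyl group the step is a 1.1-fold higher number from compound 1 to compound 3 (0.06 log units; within the scatter), so all three aryl groups sit level at this position. Nothing available explains this level outcome.

The hydroxy group cannot be separated from the different methyl placement, as both differ at once in compound 3. Going by these compounds, whether an amine or a carboxylic acid on this phenyl ring would also stay level remains open.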